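The compounds below may be only part of what the source reports. "The series", "measured", "known", "first", "only" and "open" are said of these compounds alone.

Working notes on the series. In a functional assay on PC-3 cells (Homo sapiens) for cytotoxicity, read by sulforhodamine B assay, tested at 10 uM (on this read-out higher numbers stand for more inhibition at the one concentration tested (going by the name of the read-out) and lower numbers for less inhibition), compound 1 `CC(=O)OC[C@H]1O[C@@H](n2cc(-c3cc(-c4ccc(C(C)(C)C)cc4)no3)c(=O)[nH]c2=O)C[C@@H]1OC(C)=O` gives 27.5%, compound 2 `CC(=O)OC[C@H]1O[C@@H](n2cc(-c3cc(-c4ccccc4)no3)c(=O)[nH]c2=O)C[C@@H]1OC(C)=O` gives 85.5%, and compound 3 `CC(C)(C)c1ccc(-c2cc(-c3cn([C@H]4C[C@H](O)[C@@H](CO)O4)c(=O)[nH]c3=O)on2)cc1` gives 87.9%. Compound 2 thus stands second highest of the three numbers; its value and that of compound 3 lie within the scatter of each other, while compound 1 sits far below. Among the measured compounds shown here, the one measured step, a number 58 percentage points higher from compound 1 to compound 2 (beyond the scatter), concerns the group on the distal aromatic ring. For the measured compounds named here, compound 4 `CC(=O)OC[C@H]1O[C@@H](n2cc(-c3cc(C)no3)c(=O)[nH]c2=O)C[C@@H]1OC(C)=O` differs from compound 2 by methyl in place of phenyl on an aromatic carbon, a change no measured step tests directly. Going by the values given here, because the only relevant step, a number 58 percentage points higher from compound 1 to compound 2 (beyond the scatter), shows that trimming the outer group raised inhibition, compound 4 is estimated to keep a high value, a number 20.5 percentage points lower from compound 2 to compound 4 (beyond the scatter), with wide uncertainty: estimate 65%, between 25% and 95%.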

Compound 4, a percentage reported as inhibition, at one concentration (the size of the read-out at that concentration, not a potency): 92.4%
The estimate for compound 4 lay 27.4 percentage points below the measured number, and the stated range covers the measured number.
By their numbers in this assay, from the lowest: compound 1; then compounds 2, 3 and 4 (each within the scatter of the next).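

In this assay, methyl in place of phenyl on the aromatic carbon next to the ring nitrogen gives a number 6.9 percentage points higher from compound 2 to compound 4 (within the scatter), so the phenyl ring can go from this position without a change beyond the scatter. The wider change, methyl in place of 4-(tert-butyl)phenyl, gives a number 64.9 percentage points higher from compound 1 to compound 4 (beyond the scatter), which sets compound 1 apart from both smaller groups at this position. Nothing available accounts for this result. As far as these compounds go, whether a carboxylic acid or an amine on this carbon would keep the inhibition stays open. Readings at one concentration also leave any potency difference between compound 2 and compound 4 open.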